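The compounds below may be only part of what the source reports. "The series", "measured", "known", "first", "only" and "open" are said of these compounds alone.

For the measured compounds named here, in an ADME assay on HeLa cells (Homo sapiens) for cytotoxicity, read by crystal violet staining, with a stated time of 72 h (on this read-out higher numbers stand for lower toxicity in this test and lower numbers for higher toxicity in this test), compound 1 `CCOC(=O)c1cc(CCCOc2ccc(-c3noc(C(F)(F)F)n3)cc2F)on1` gives 60200 nM as the highest of the three numbers so far. Compound 2 `CN(C)C(=O)c1cc(CCCOc2ccc(-c3noc(C(F)(F)F)n3)cc2F)on1` gives 20200 nM and compound 3 `COc1cc(-c2noc(C(F)(F)F)n2)cc([N+](=O)[O-])c1OCCCc1cc(C(=O)N(C)C)no1` gives 25600 nM and each of these two lies beyond the scatter below compound 1. Compound 4 `CCOC(=O)c1cc(CCCOc2ccc(-c3noc(C(F)(F)F)n3)cc2-n2cccc2)on1` has not been measured yet. It differs from compound 1 in one place 1H-pyrrol-1-yl in place of fluoro on an aromatic carbon with 1H-pyrrol-1-yl in place of fluoro on an aromatic carbon, ortho to a large group. The only measured step between two of these compounds is a 3.0-fold lower number from compound 1 to compound 2 (0.47 log units; beyond the scatter) for dimethylamino in place of ethoxy on a carbonyl carbon. Going by the values given here, that step is modest and concerns a different group, and no measured step replaces the fluoro group, so it offers only a rough guide to size. A modest move towards a lower number is therefore expected, and the estimated step is a 2.0-fold lower number from compound 1 to compound 4 (0.30 log units; within the scatter) with wide uncertainty. The estimate for compound 4 is 30000 nM with 10000 nM to 80000 nM as the expected range.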

Compound 4, half-maximal cytotoxic concentration: 57300 nM
Estimate against measurement, compound 4: 1.9-fold (0.28 log units) below; the range from low to high includes it.
By their numbers in this assay, from the lowest: compounds 2 and 3 (each within the scatter of the next); then compounds 4 and 1 (each within the scatter of the next).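

In this assay, replacing fluoro with 1H-pyrrol-1-yl on an aromatic carbon, ortho to a large group, gives a step that cannot be told apart from repeat-measurement noise (a 1.1-fold lower number from compound 1 to compound 4 (0.02 log units; within the scatter)). For the compounds shown here, the only earlier step concerned the group on the carbonyl carbon, so this is the first reading at the fluoro position, where five heavy atoms and a five-membered aromatic ring take the place of a single fluorine with no difference beyond the scatter. No supporting measurement is available to explain this result.

An amine, a carboxylic acid or a methyl group at this position could give a different result, and one replacement here sets no trend with group size. From the compounds shown here alone, it also remains open whether 1H-pyrrol-1-yl would give the same result with dimethylamino in place of ethoxy on the carbonyl carbon, as in compound 2.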